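The source may report more compounds than this note shows. Statements on the series, on what has been measured and on what is new or still open speak of the compounds shown alone.

Three measured analogues share one core. Compound 1 `COc1cc2c(Oc3ccc(NC(=O)c4cc(-c5ccc(F)cc5)on4)cc3)ccnc2cc1OCCCN1CCC(C)CC1` gives 24600 nM in a functional assay on HT-29 cells (Homo sapiens) for antiproliferative activity, read by MTT assay, with a stated time of 72 h (on this read-out higher numbers stand for weaker inhibition and lower numbers for stronger inhibition), the highest of the three numbers. Compound 2 `COc1cc2c(Oc3ccc(NC(=O)c4nc(-c5ccc(F)cc5)no4)cc3)ccnc2cc1OCCCN1CCC(C)CC1` gives 6380 nM in this assay, and compound 3 `COc1cc2c(Oc3ccc(NC(=O)c4nnc(-c5ccc(F)cc5)o4)cc3)ccnc2cc1OCCCN1CCC(C)CC1` gives 7890 nM in this assay. Both steps away from compound 1 lower the number, a 3.9-fold lower number from compound 1 to compound 2 (0.59 log units; beyond the scatter) and a 3.1-fold lower number from compound 1 to compound 3 (0.49 log units; beyond the scatter), while a 1.2-fold higher number from compound 2 to compound 3 (0.09 log units; within the scatter) stays within the scatter.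

Compound 4 `COc1cc2nccc(Oc3ccc(NC(=O)c4cc(-c5ccc(F)cc5)on4)cc3)c2cc1OC` differs from compound 1 in a different place altogether: hydrogen in place of 2-(4-methylpiperidin-1-yl)ethyl on a saturated chain carbon bound to an oxygen on an aromatic ring; cut one bond further out, 3-(4-methylpiperidin-1-yl)propoxy becomes methoxy. For the measured compounds named here, none of the measured steps touches this side chain; each of them alters the group on the carbonyl carbon while the 3-(4-methylpiperidin-1-yl)propoxy side chain is kept. Going by the values given here, no measured step therefore bears on the change, and no direction can be read from the set. The expectation for compound 4 in this assay is a step within the scatter, a 1.2-fold higher number from compound 1 to compound 4 (0.09 log units; within the scatter), with wide uncertainty. Compound 4 is accordingly estimated at 30000 nM, range 9000 nM to 100000 nM.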

Compound 4, half-maximal inhibitory concentration: > 100000 nM
Compound 4: no number, only a limit; the forecaster's own chance of this, stated with the estimate: 25%; at least 3.3-fold (0.52 log units) between middle value and limit.
By their numbers in this assay, from the lowest: compounds 2 and 3 (each within the scatter of the next); then compound 1. At a limit, above all of these: compound 4.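

Methoxy in place of 3-(4-methylpiperidin-1-yl)propoxy brings an at least 4.0-fold higher number from compound 1 to compound 4 (0.60 log units; beyond the scatter), so the side chain position matters in this assay, whereas all earlier steps altered only the group on the carbonyl carbon. Compound 4 reads > 100000 nM, which is a limit of the assay and not a number. The size of this step therefore stays open on the upper side, bounded only by this limit: the limit of > 100000 nM in this assay, at which 1 of the 4 values shown sits.

On these data alone, whether the change has a similar outcome with 3-(4-fluorophenyl)-1,2,4-oxadiazol-5-yl or 5-(4-fluorophenyl)-1,3,4-oxadiazol-2-yl on the carbonyl carbon remains open. Also open, as far as these compounds go, is which part of the side chain matters: a morpholine in place of the 4-methylpiperidine, a shorter chain ending in a dimethylamine, or a propoxy chain with no terminal amine would separate the amine from the chain.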